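This account rests on a few compounds, and the source may have more. Where it says the series, first, only, none or still open, it means among the compounds named here.

Of the compounds shown here, two of a shared core have been measured in an assay on Cerebral cortex for binding affinity to adenosine receptor A1 (Cavia porcellus), read by radioligand binding; on this read-out lower numbers stand for stronger inhibition and higher numbers for weaker inhibition. Compound 1, with structure `CCCn1c(=O)n(CCOCC)c(=O)c2[nH]cnc21`, gives 1900 nM. Compound 2, with structure `CCCn1c(=O)n(C)c(=O)c2c1ncn2CCC#N`, gives 88600 nM. Compound 2 thus stands at the higher of the two numbers, and the gap between compound 1 and compound 2 lies well beyond the usual scatter of this assay; the two structures differ in more than one place, so no single change can be tied to that gap.

Compound 3, with structure `CCCn1c(=O)n(C)c(=O)c2c1ncn2CCOCC`, has not yet been measured. It differs from compound 2 in one place: ethoxy in place of cyano on a saturated chain carbon, two bonds along the chain from an aromatic nitrogen. The rest of the structure stays as in compound 2.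

For the measured compounds named here, no measured pair shows this change on its own, so the expectation for compound 3 rests only on the two numbers given. Because compound 2 gives 88600 nM, the step is expected to be modest, a 2.0-fold lower number from compound 2 to compound 3 (0.29 log units; within the scatter), and toward a somewhat lower number. On that basis compound 3 is estimated at 45000 nM, within a range from 15000 nM to 150000 nM.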

Compound 3, inhibition constant: 24300 nM
Compound 3: middle estimate off by 1.9-fold (0.27 log units), on the high side; the measured number falls inside the stated range.
By their numbers in this assay, from the lowest: compound 1; then compound 3; then compound 2.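

Replacing cyano with ethoxy, on a saturated chain carbon, two bonds along the chain from an aromatic nitrogen, gives a 3.6-fold lower number from compound 2 to compound 3 (0.56 log units; beyond the scatter) in this assay. For the compounds shown here, this is the first change in the set that can be read on its own, and it shows that the number responds to what sits at the end of this chain, something the gap between compound 1 and compound 2 could not show. The swap adds one heavy atom, going from 2 to 3, and keeps the count of hydrogen-bond acceptors at 1, but nothing measured here explains the lower number.

A single step cannot show whether the response comes from the oxygen, from the extra carbon or from the two together, nor how an amine, a carboxylic acid or a longer chain would fare at the same place. It also leaves open whether the same swap would shift the number in the same direction if the methyl on the shared core were replaced by another group.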